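The source may hold more compounds than are shown below. What is called first, only, known or untested is meant among the compounds shown, and "the series" means these compounds.

Measured so far:
compound 1, `CCOc1ccc(-c2nc(OC)c(NC(CC)CC)nc2C)c(Cl)c1`: 0.783 h
compound 2, `CCc1nc(NC(CC)CC)c(OC)nc1-c1ccc(OC)cc1C(F)(F)F`: 2 h
compound 3, `CCCN(CCN(C)C)c1nc(CC)c(-c2ccc(Cl)cc2Cl)nc1CC`: < 0.0167 h

In an in vitro ADME assay on microsomes (Rattus norvegicus) for metabolic stability (a lower number here means that the compound disappears faster, a higher number that the compound lasts longer), compound 2 gives the highest of the two numbers shown. The nearest to it is compound 1, whose value sits beyond the scatter below that of compound 2. Compound 3 is not given as a number: its result is a limit of this assay, (the limit of < 0.0167 h in this assay, at which 1 of the 3 values shown sits).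

Compound 4, `CCc1nc(-c2ccc(OC)cc2C(F)(F)F)c(CC)nc1NC(CC)CC`, has not yet been measured in this assay. It differs from compound 2 in one place: ethyl in place of methoxy on an aromatic carbon.

For the measured compounds named here, no pair of measured compounds differing in a single place is available to guide the size of this step. Compound 3 also carries ethyl groups on its core, but it differs from compound 2 in several other places as well, so its limit says little about the change from methoxy to ethyl alone. The step from compound 2 to compound 4 is therefore expected to be small, a 1.7-fold lower number from compound 2 to compound 4 (0.22 log units; within the scatter), and may well lie within the scatter. Compound 4 is estimated to give 1.2 h in this assay, with a range from 0.4 h to 3 h.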

Compound 4, half-life: 0.0717 h
Beside the measured number, compound 4's estimate is 17-fold (1.22 log units) above it; the measured number lies below the stated range.
By their numbers in this assay, from the lowest: compound 4; then compound 1; then compound 2. At a limit, below all of these: compound 3.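

In this assay, the position next to the ring nitrogen and ortho to the (pentan-3-yl)amino group proves sensitive: ethyl in place of methoxy there gives a 28-fold lower number from compound 2 to compound 4 (1.45 log units; beyond the scatter), a large step and the first single-place comparison available. The two groups have the same heavy-atom count, and the change removes only the oxygen and its hydrogen-bond acceptor, so a swap of equal size can still move this number far beyond the scatter. No measurement shown gives a reason for this step.

The compounds shown leave open whether the step belongs to ethyl itself or to the absence of methoxy; a methyl, a hydroxyl or an amine at this position would help separate the two. They also leave open whether the step keeps its size with a shorter chain in place of the (pentan-3-yl)amino group.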